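A few compounds are considered here, and "the series" means these few. Any claim that something is new, unique, unknown or untested is made for them only; others in the source may bear on it.

Compound 1, `Cc1ccc2c(n1)c(C(=O)N[C@H]1CCOC[C@@H]1O)cn2Cc1ccc(-c2ccn(C)n2)cc1`: in an ADME assay on liver for metabolic stability, with Liver microsome (Homo sapiens) as the target, using microsomes (on this read-out lower numbers stand for slow clearance and higher numbers for fast clearance), compound 1 gives < 8 mL/min/kg, which is a limit of the assay and not a number.
Compound 2, `O=C(NC[C@@H]1CCCO1)c1cn(Cc2ccc(-n3cccn3)cc2)c2cccnc12`: in this assay compound 2 gives 133 mL/min/kg.
Compound 3, `Cn1ccc(NC(=O)c2cn(Cc3ccc(-n4cccn4)cc3)c3cccnc23)n1`: in this assay compound 3 gives 31 mL/min/kg.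

Compound 1 stands at the low end of what is shown, because of the limit of < 8 mL/min/kg in this assay, at which 1 of the 3 values shown sits. For the measured compounds named here, the only measured step, a 4.3-fold lower number from compound 2 to compound 3 (0.63 log units; beyond the scatter), concerns the amide substituent and not the change at hand. Compound 4, `Cn1ccc(-c2ccc(Cn3cc(C(=O)N[C@H]4CCOC[C@@H]4O)c4ncccc43)cc2)n1`, differs from compound 1 by hydrogen in place of methyl on an aromatic carbon. Going by the values given here, no measured step bears on this change, so there is no ground to expect movement beyond the scatter in this assay. Compound 4 is therefore expected to sit near compound 1, with an estimated step that the limit leaves unreadable from compound 1 to compound 4. The estimate for compound 4 is 6 mL/min/kg, with a range from 3 mL/min/kg to 15 mL/min/kg.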

Compound 4, clearance: 10.6 mL/min/kg
Estimate against measurement, compound 4: 1.8-fold (0.25 log units) below; measured number inside the range.
By their numbers in this assay, from the lowest: compound 4; then compound 3; then compound 2. At a limit, below all of these: compound 1.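

Hydrogen in place of methyl on the aromatic carbon next to the ring nitrogen gives, in this assay, an at least 1.3-fold higher number from compound 1 to compound 4 (0.12 log units; that floor lies within the scatter). For the compounds shown here, this is the first reading at this position, and with the methyl gone compound 4 gives 10.6 mL/min/kg. The full size of the step cannot be read, so no effect of the methyl is shown, because the value of compound 1 is a limit: the limit of < 8 mL/min/kg in this assay, at which 1 of the 4 values shown sits.

The compounds shown leave open how a chlorine, a methoxy or an ethyl on this carbon would read. They also leave open whether the change behaves alike with another amide substituent.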